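Series notes: acetyl to bromo on the pendant phenyl

A few compounds are considered here, and "the series" means these few. Any claim that something is new, unique, unknown or untested is made for them only; others in the source may bear on it.

Among the compounds with values here, compound 2 `CC(=O)c1ccc(-c2cn3ccnc3c(-c3ccc4ncn(C5CCCCC5)c4c3)n2)cc1` has the lower of the two numbers measured so far: in a functional assay on MDA-MB-231 cells (Homo sapiens) for inhibition, read by sulforhodamine B assay, with a stated time of 48 h, tested at 10 uM (a higher number here means more inhibition at the concentration tested (going by the name of the read-out), a lower number less inhibition), compound 2 gives 7.65%, while compound 1 `c1ccc(-c2cn3ccnc3c(-c3ccc4ncn(C5CCCCC5)c4c3)n2)cc1` gives 41.5% in this assay. Within the data shown here, the one step measured, a number 33.9 percentage points lower from compound 1 to compound 2 (beyond the scatter), shows that putting acetyl onto that aromatic carbon costs a large share of the inhibition. Compound 3 `Brc1ccc(-c2cn3ccnc3c(-c3ccc4ncn(C5CCCCC5)c4c3)n2)cc1` now carries the change (bromo in place of acetyl on an aromatic carbon). Among the measured compounds shown here, no measured step covers hydrogen against bromo at this position, so the only guide is that the acetyl group, whose introduction drove the drop in compound 2, is removed again. Replacing it rather than simply deleting it leaves the outcome open, but a recovery toward compound 1 is the expectation; a step of a number 22.4 percentage points higher from compound 2 to compound 3 (beyond the scatter) in this assay is expected. Compound 3 is therefore estimated at 30%, within 10% to 50%, pending the measurement.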

Compound 3, a percentage reported as inhibition, at one concentration (the size of the read-out at that concentration, not a potency): 22.8%
For compound 3 the middle estimate is 7.2 percentage points above the measured one, and the stated range covers the measured number.
By their numbers in this assay, from the lowest: compound 2; then compound 3; then compound 1.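

In this assay the change from 4-acetylphenyl to 4-bromophenyl gives a number 15.2 percentage points higher from compound 2 to compound 3 (beyond the scatter) and so brings back part of the inhibition, which shows that the low reading of compound 2 is not common to every group on this aromatic carbon. Bromo still falls short of hydrogen, with a number 18.7 percentage points lower from compound 1 to compound 3 (beyond the scatter) and this shows that even a single heavy atom here lowers the reading, so both substituents seen so far sit under the unsubstituted compound 1. Nothing available explains this order of hydrogen, bromo and acetyl.

Going by these compounds, whether an amine or a carboxylic acid on this carbon would hold the level of compound 1 or fall like bromo and acetyl stays open. Also open, on these data alone, is whether a methoxy group would follow the same order, and whether that order would hold at another concentration.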